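Ester Variation in a Thromboxane Synthase Inhibitor Series

The source may hold more compounds than are shown below. What is called first, only, known or untested is meant among the compounds shown, and "the series" means these compounds.

Measured compounds:
Compound 1 `COc1ccc(COCC(Cn2ccnc2)OCc2ccc(OC)cc2)cc1` gives 9900 nM in a functional assay for inhibition of Thromboxane-A synthase (Homo sapiens); a lower number here means a stronger inhibitor, a higher number a weaker inhibitor.
Compound 2 `CCCOC(=O)c1ccc(COC(COCc2ccc(OC)cc2)Cn2ccnc2)cc1` gives 180 nM in this assay.
Compound 3 `CCCCOC(=O)c1ccc(COC(COCc2ccc(OC)cc2)Cn2ccnc2)cc1` gives 200 nM in this assay.

All three share a core in which an imidazole hangs from a short chain bearing two benzyl ethers. In compound 1 both rings carry a methoxy group. Replacing one methoxy by an ester gives a large gain: a 55-fold lower number from compound 1 to compound 2 (1.74 log units; beyond the scatter) and a 50-fold lower number from compound 1 to compound 3 (1.69 log units; beyond the scatter). Between the two esters the change is small: a 1.1-fold higher number from compound 2 to compound 3 (0.05 log units; within the scatter). Compound 3 therefore sits among the two stronger inhibitors, within the scatter of compound 2 and far from compound 1.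

Compound 4 `COc1ccc(COCC(Cn2ccnc2)OCc2ccc(C(=O)Oc3ccccc3)cc2)cc1` keeps the ester but alters the group on its oxygen: phenyl in place of butyl on an oxygen next to a carbonyl group. Among the measured compounds shown here, no measured step touches this position; the only ester-side step, from propyl to butyl, stayed within the scatter. The expectation is a small move at most, a 1.3-fold higher number from compound 3 to compound 4 (0.10 log units; within the scatter), without a clear direction. Compound 4 is thus estimated at 250 nM in this assay, with a range from 80 nM to 800 nM.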

Compound 4, half-maximal inhibitory concentration: 560 nM
Compound 4: the middle estimate sits 2.2-fold (0.35 log units) below what was measured; low and high end bracket the measured number.
By their numbers in this assay, from the lowest: compounds 2 and 3 (each within the scatter of the next); then compound 4; then compound 1.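

The group on the ester oxygen turns out to matter: in this assay phenyl in place of butyl gives a 2.8-fold higher number from compound 3 to compound 4 (0.45 log units; beyond the scatter) and phenyl in place of propyl gives a 3.1-fold higher number from compound 2 to compound 4 (0.49 log units; beyond the scatter) as well, both beyond the scatter, whereas the earlier change from propyl to butyl stayed within it. The ester with a phenyl group still keeps much of the gain over the methoxy group, with an 18-fold lower number from compound 1 to compound 4 (1.25 log units; beyond the scatter) as the step, so swapping butyl for this six-membered aromatic ring gives back only part of what the ester brought. No supporting measurement bears on why the phenyl ester stands apart from the two chain esters, so this remains a plain observation.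

The compounds shown leave open whether the ring itself or simply the larger group counts here, and a cyclohexyl group on the same oxygen would help separate the two. Also open, going by these compounds, is whether the ester itself is needed for the gain over methoxy, a question that a carboxylic acid or an amide in its place would address.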